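One Inverted Stereocentre and Microsomal Clearance

A few compounds are considered here, and "the series" means these few. Any claim that something is new, unique, unknown or untested is made for them only; others in the source may bear on it.

Measured so far:
- Compound 1 `COc1ccc(Cc2cc([C@]34OC[C@](CO)(O3)[C@@H](O)[C@H](O)[C@H]4O)ccc2C)cc1` with < 8 mL.min-1.g-1 (a limit of the assay)
- Compound 2 `COc1ccc(Cc2cc([C@]34OC[C@](CO)(O3)[C@@H](O)[C@H](O)[C@H]4O)ccc2Cl)cc1` with 9.2 mL.min-1.g-1 (a measured number)

Among the compounds with values here, in an in vitro ADME assay on microsomes from liver (Homo sapiens) for metabolic stability (a lower number here means slower removal, a higher number faster removal of the compound), compound 2 gives 9.2 mL.min-1.g-1 as the only true number so far. Compound 1 gives only a limit of the assay (the limit of < 8 mL.min-1.g-1 in this assay, at which 1 of the 2 values shown sits) and not a number.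

Within the data shown here, the one measured step, an at least 1.1-fold higher number from compound 1 to compound 2 (0.06 log units; that floor lies within the scatter) (chloro in place of methyl on an aromatic carbon), concerns a different place in the structure and does not test configuration. Compound 3 `COc1ccc(Cc2cc([C@]34OC[C@](CO)(O3)[C@@H](O)[C@H](O)[C@@H]4O)ccc2Cl)cc1` stands apart from compound 2 in one respect (the two compounds have the same atoms and bonds and differ only in configuration as drawn: 1 of 5 stereo elements differ; a stereocentre at a saturated ring carbon is drawn R in compound 2 and S in compound 3). Among the measured compounds shown here, no measured pair tests such an inversion, so the data give no direction for a change in this assay and offer only the small step already seen as a guide. The expected step (a 1.0-fold higher number from compound 2 to compound 3 (0.01 log units; within the scatter)) is therefore no larger than the scatter. For compound 3 the estimated value is 9.5 mL.min-1.g-1 with an expected range from 8 mL.min-1.g-1 to 18 mL.min-1.g-1 in this estimate.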

Compound 3, intrinsic clearance in microsomes: 15 mL.min-1.g-1
Compound 3: middle estimate off by 1.6-fold (0.20 log units), on the low side; the measured number falls inside the stated range.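

Within the data shown here, the pair of compound 2 and compound 3 is the first to test configuration, here at a saturated ring carbon drawn R in one compound and S in the other. In this assay, this inversion gives a 1.6-fold higher number from compound 2 to compound 3 (0.21 log units; within the scatter), so the two compounds cannot be told apart in this read-out, and the data show no sign that this stereocentre governs removal in microsomes. This comparison is unusually clean, as no group enters or leaves and only this stereocentre can account for any real difference between the two compounds: the fact that compounds 2 and 3 differ only in the configuration as drawn

On these data alone, the inversion has been read only with the chloro group in place, and compound 1, which carries methyl instead, gives only a limit of the assay, < 8 mL.min-1.g-1, so the same inversion with methyl remains open. Also open, as far as these compounds go, are the effect of inverting any of the other stereo elements in the shared core and how this assay would respond to an amine or a fluoro group at this saturated ring carbon.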